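This account rests on a few compounds, and the source may have more. Where it says the series, first, only, none or still open, it means among the compounds named here.

In a functional assay on SV5A8 cells (Homo sapiens) for cytotoxicity (on this read-out higher numbers stand for weaker inhibition and lower numbers for stronger inhibition), compound 1, `Cc1ccc2c(NCc3ccc(NC(=O)C4CCN(Cc5cccc(F)c5)CC4)cc3)nc(N(C)C)nc2c1`, yields only a limit, > 4170 nM, and not a number. Compound 2, `Cc1ccc2c(NCc3ccc(NC(=O)C4CCN(Cc5ccccc5)CC4)cc3)nc(N3CCN[C@@H](C)C3)nc2c1`, likewise reaches only a limit in this assay, > 8860 nM. Both values sit at the edge of what this assay reports, as shown by the limit of > 4170 nM in this assay, at which 1 of the 2 values shown sits, and (the limit of > 8860 nM in this assay, at which 1 of the 2 values shown sits), so compound 1 stands nowhere in particular among the numbers: neither compound has a measured inhibitory concentration, and nothing can be said about an order between them.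

Compound 3, `Cc1ccc2c(NCc3ccc(NC(=O)C4CCN(C)CC4)cc3)nc(N(C)C)nc2c1`, is the unmeasured partner of compound 1. It differs from compound 1 by hydrogen in place of 3-fluorophenyl on a saturated chain carbon bound to an amine nitrogen in a ring. Among the measured compounds shown here, with no measured step available, the expectation is that compound 3 shows nothing beyond the scatter relative to compound 1, with a fair chance that this assay again returns only a limit. The step that the limit leaves unreadable from compound 1 to compound 3 is therefore expected to be flat. Compound 3 is estimated to give about 10000 nM in this assay, within a range from 3000 nM to 40000 nM.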

Compound 3, half-maximal inhibitory concentration: > 17300 nM
Compound 3 was reported as a limit; the forecaster's own chance of this, stated with the estimate: 75%; middle value at least 1.7-fold (0.23 log units) from the limit.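

In this assay compound 3 gives only the limit > 17300 nM and not a number. Compound 1 likewise gives only the limit > 4170 nM here, so the step between compound 1 and compound 3 cannot be read. The compounds shown leave open whether 3-fluorobenzyl to methyl changes cytotoxicity at all.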